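Adding a Chloro Group to the Weakest Compound

The compounds below may be only part of what the source reports. "The series", "measured", "known", "first", "only" and "open" are said of these compounds alone.

Compound 1 `Cc1nc(C)c(/C=C/C(=O)/C=C/c2ccccc2O)nc1C` gives 4780 nM
Compound 2 `COc1ccc(/C=C/C(=O)/C=C/c2nc(C)c(C)nc2C)cc1` gives 3500 nM
Compound 3 `Cc1nc(C)c(/C=C/C(=O)/C=C/c2ccccc2)nc1C` gives 12300 nM

In a functional assay on A549 cells (Homo sapiens) for antiproliferative activity, read by MTT assay, with a stated time of 72 h (a higher number here means a weaker inhibitor, a lower number a stronger inhibitor), compound 3 has the highest number of the three, and its steps to both others lie beyond the scatter, so it is the weakest of this small set. Compound 4 `Cc1nc(C)c(/C=C/C(=O)/C=C/c2ccc(Cl)cc2)nc1C` keeps the core of compound 3 and makes one change, chloro in place of hydrogen on an aromatic carbon which turns phenyl into 4-chlorophenyl. Going by the values given here, no chloro compound has been measured, so the nearest guides are two other single changes. Swapping hydroxy for hydrogen gave a 2.6-fold higher number from compound 1 to compound 3 (0.41 log units; beyond the scatter) and swapping methoxy for hydrogen gave a 3.5-fold higher number from compound 2 to compound 3 (0.55 log units; beyond the scatter) and both steps are modest. Read backwards, each shows a lower number when a group replaces hydrogen on the bare phenyl. A similar modest drop is therefore expected, estimated as a 2.2-fold lower number from compound 3 to compound 4 (0.35 log units; beyond the scatter) in this assay and hydroxy and methoxy remain only rough stand-ins for chloro. Compound 4 is estimated at 5500 nM with 2300 nM to 13000 nM as the expected range.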

Compound 4, half-maximal inhibitory concentration: 15800 nM
The estimate for compound 4 lay 2.9-fold (0.46 log units) below the measured number; the whole stated range lies below it.
By their numbers in this assay, from the lowest: compounds 2 and 1 (each within the scatter of the next); then compounds 3 and 4 (each within the scatter of the next).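

In this assay the change from phenyl to 4-chlorophenyl gives a 1.3-fold higher number from compound 3 to compound 4 (0.11 log units; within the scatter) so at this place, para to a large group, chloro cannot be told apart from hydrogen, and replacing hydrogen on the bare phenyl does not always go with a lower number. What matters here is which group enters, not merely that one does: chloro in place of methoxy gives a 4.5-fold higher number from compound 2 to compound 4 (0.65 log units; beyond the scatter) and 4-chlorophenyl in place of 2-hydroxyphenyl gives a 3.3-fold higher number from compound 1 to compound 4 (0.52 log units; beyond the scatter) and both steps are modest. Nothing available explains why chloro and methoxy part ways in this assay.

Going by these compounds, it remains open whether an amine, a carboxylic acid or a fluoro group at this place would follow methoxy or chloro. Chloro on another carbon of the ring also remains an open case.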